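Sulfonyl Substituent Exchange on a Shared Core

The compounds below may be only part of what the source reports. "The series", "measured", "known", "first", "only" and "open" are said of these compounds alone.

compound 1 `CCCn1c(=O)c(S(=O)(=O)c2ccc(F)cc2F)cc2cnc(Nc3ccc4[nH]ccc4c3)nc21`: 1000 nM
compound 2 `Cn1c(=O)c(S(=O)(=O)Cc2ccc(F)cc2F)cc2cnc(Nc3ccc4[nH]ccc4c3)nc21`: 1000 nM
compound 3 `Cc1ccc(S(=O)(=O)c2cc3cnc(Nc4cnc5[nH]ccc5c4)nc3n(C)c2=O)cc1`: 25000 nM

In a functional assay on DU-145 cells (Homo sapiens) for inhibition, read by trypan blue exclusion, with a stated time of 72 h (a lower number here means a stronger inhibitor, a higher number a weaker inhibitor), compound 2 gives 1000 nM, level with compound 1 at the digits shown and together the lowest of the three numbers; compound 3 sits far above both. Compound 4 `Cn1c(=O)c(S(=O)(=O)c2ccc(N)cc2F)cc2cnc(Nc3ccc4[nH]ccc4c3)nc21` has not been measured. It differs from compound 2 in one place: 4-amino-2-fluorophenyl in place of 2,4-difluorobenzyl on a sulfonyl sulfur. Among the compounds with values here, no measured pair isolates this change, so the size of the step is uncertain. Compound 1, which also carries an aryl group on the sulfonyl sulfur, matches compound 2, so no step beyond the scatter is expected from compound 2 to compound 4 in this assay, a 1.3-fold lower number from compound 2 to compound 4 (0.10 log units; within the scatter). Compound 4 is therefore estimated at 800 nM, in a range from 200 nM to 4000 nM.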

Compound 4, half-maximal inhibitory concentration: 8000 nM
The estimate for compound 4 lay 10-fold (1.00 log units) below the measured number, and the stated range ends below it.
By their numbers in this assay, from the lowest: compounds 1 and 2 (each within the scatter of the next); then compound 4; then compound 3.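

In this assay the substituent on the sulfonyl sulfur proves not to be interchangeable: 4-amino-2-fluorophenyl in place of 2,4-difluorobenzyl gives an 8.0-fold higher number from compound 2 to compound 4 (0.90 log units; beyond the scatter). Within the data shown here, this is the first single-place change that can be read at this position, and its size exceeds the scatter. Nothing available accounts for the step. Open, as far as these compounds go, is whether the amine or the change from benzyl to phenyl carries it, as the two change together here. Also open, from the compounds shown here alone, is how a 4-amino-2-fluorobenzyl group, or a hydroxyl or methoxy in place of the amine, would read.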